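The source may hold more compounds than are shown below. What is called first, only, known or untested is meant among the compounds shown, and "the series" means these compounds.

In a functional assay on LS174T cells (Homo sapiens) for inhibition, with a stated time of 4 days, tested at 1 uM (a higher number here means a stronger effect of the compound at the concentration tested, a lower number a weaker effect), compound 3 `Nc1ncc(C#Cc2c(F)cccc2F)c2ccccc12` gives 86.2%, the highest of the three numbers: compound 2 `Fc1cccc(F)c1C#Cc1cnc(Cl)c2ccccc12` gives 48.1% and compound 1 `Fc1cccc(F)c1C#Cc1cncc2ccccc12` gives 16.5%. The unmeasured compound 4 `CN(C)c1ncc(C#Cc2c(F)cccc2F)c2ccccc12` differs from compound 3 in one place: dimethylamino in place of amino on an aromatic carbon. Within the data shown here, no measured step swaps amino for dimethylamino; the nearest evidence is a number 38.1 percentage points higher from compound 2 to compound 3 (beyond the scatter) and a number 69.7 percentage points higher from compound 1 to compound 3 (beyond the scatter), both large gains on arrival of the amino group with its one hydrogen-bond donor. With that donor gone in compound 4, the step in this assay is expected to be a number 31.2 percentage points lower from compound 3 to compound 4 (beyond the scatter), though how much of the gain survives is uncertain. The estimate for compound 4 is 55%, with a range from 25% to 85%.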

Compound 4, a percentage reported as inhibition, at one concentration (the size of the read-out at that concentration, not a potency): 99.5%
The estimate for compound 4 lay 44.5 percentage points below the measured number; measured number outside the range, above it.
By their numbers in this assay, from the lowest: compound 1; then compound 2; then compound 3; then compound 4.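

In this assay, dimethylamino in place of amino at this carbon next to the ring nitrogen gives a number 13.3 percentage points higher from compound 3 to compound 4 (beyond the scatter), so among these compounds a high number does not require the hydrogen-bond donor of amino. The lead of dimethylamino over the other groups is also clear, with a number 51.4 percentage points higher from compound 2 to compound 4 (beyond the scatter) for the change from chloro and a number 83 percentage points higher from compound 1 to compound 4 (beyond the scatter) for the change from hydrogen. Nothing measured here explains why this change raises the number.

Open, from the compounds shown here alone, is whether methylamino, which lies between amino and dimethylamino, would fall between them in this read-out. Also open, going by these compounds, is whether a cyclic amine such as pyrrolidine or morpholine would hold the effect at this carbon.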